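Methoxy for Methylsulfonyl on a Weakly Active Scaffold

The compounds below may be only part of what the source reports. "The series", "measured", "known", "first", "only" and "open" are said of these compounds alone.

Compound 1, `CS(=O)(=O)c1ccc(-c2csc(N3N=C(c4ccc(Cl)s4)CC3c3ccc(F)cc3)n2)cc1`, shows no measurable potency: in a functional assay on A549 cells (Homo sapiens) for antiproliferative activity, read by XTT assay, with a stated time of 24 h (a lower number here means a stronger inhibitor, a higher number a weaker inhibitor), compound 1 gives > 500 ug/mL, which is a limit of the assay rather than a number. Its neighbour compound 2, `Cc1ccc(C2=NN(c3nc(-c4ccc(S(C)(=O)=O)cc4)cs3)C(c3ccc(F)cc3)C2)s1`, carries a methyl in place of chloro on an aromatic carbon. In this assay compound 2 gives > 500 ug/mL, again a limit. Within the data shown here, the step that the two limits leave unreadable from compound 1 to compound 2 therefore cannot be sized, and the only evidence available is the limit of > 500 ug/mL in this assay, at which 2 of the 2 values shown sit.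

Compound 3, `COc1ccc(-c2csc(N3N=C(c4ccc(Cl)s4)CC3c3ccc(F)cc3)n2)cc1`, differs from compound 1 by methoxy in place of methylsulfonyl on an aromatic carbon. No measured step touches the methylsulfonyl position, so the shown data give no direction for this change. With both measured values resting at the limit, compound 3 is expected to give about 500 ug/mL in this assay, within 150 ug/mL to 1000 ug/mL, most likely reported again only as a limit. The step of a number no higher from compound 1 to compound 3 (the limit leaves the size open) is thus expected to be none beyond the scatter.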

Compound 3, half-maximal inhibitory concentration: > 500 ug/mL
Compound 3: no number, only a limit; the forecaster's own chance of this, stated with the estimate: 70%; the middle value sits exactly at the limit.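

Compound 1 and compound 3 both rest at a limit of the assay rather than at a number, so no size can be read for the step between them: the limit of > 500 ug/mL in this assay, at which 3 of the 3 values shown sit.

The compounds shown leave open whether going from 4-(methylsulfonyl)phenyl to 4-methoxyphenyl changes potency at all in this assay, and which change to the shared core would give a readable number.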